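A few compounds are considered here, and "the series" means these few. Any claim that something is new, unique, unknown or untested is made for them only; others in the source may bear on it.

Compound 1, `CN1[C@@H]2c3[nH]c4ccccc4c3C[C@H]1[C@H](C#N)N1[C@@H](CNC(=O)c3ccc(Cl)cc3)c3[nH]c4ccccc4c3C[C@@H]21`, in a functional assay on HepG2 cells (Homo sapiens) for cytotoxicity, read by MTT assay, with a stated time of 72 h; on this read-out lower numbers stand for stronger inhibition and higher numbers for weaker inhibition: 350 nM
Compound 2, `CN1[C@@H]2c3[nH]c4ccccc4c3C[C@H]1[C@H](C#N)N1[C@@H](CNC(=O)c3cccc4c3CCCC4)c3[nH]c4ccccc4c3C[C@@H]21`, in this assay: 540 nM
Compound 3, `CN1[C@@H]2c3[nH]c4ccccc4c3C[C@H]1[C@H](C#N)N1[C@@H](CNC(=O)/C=C/c3cccc(C(F)(F)F)c3)c3[nH]c4ccccc4c3C[C@@H]21`, in this assay: 540 nM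

These three compounds share one core and differ only in the group on the carbonyl carbon of the amide. Compound 3 stands level with compound 2, and the two together give the highest numbers of the three; compound 1 lies at the other end, though the gap is a 1.5-fold higher number from compound 1 to compound 3 (0.19 log units; within the scatter). Compound 4, `COc1ccc(/C=C/C(=O)NC[C@H]2c3[nH]c4ccccc4c3C[C@H]3[C@H]4c5[nH]c6ccccc6c5C[C@@H]([C@H](C#N)N23)N4C)cc1`, differs from compound 3 by 4-methoxyphenyl in place of 3-(trifluoromethyl)phenyl on a double-bonded chain carbon bound to a double-bonded chain carbon. The two steps that bear on this change swapped the whole group on the carbonyl carbon: a 1.5-fold higher number from compound 1 to compound 3 (0.19 log units; within the scatter) and no change at the digits printed from compound 2 to compound 3 (within the scatter). Both stayed within the scatter, and the change to compound 4 is a smaller one, leaving the ethenyl chain and amide untouched. No step beyond the scatter is therefore expected: no change at the digits printed from compound 3 to compound 4 (within the scatter). Compound 4 is estimated at 540 nM, with a range from 250 nM to 1200 nM.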

Compound 4, half-maximal inhibitory concentration: 2140 nM
The estimate for compound 4 lay 4.0-fold (0.60 log units) below the measured number; measured number outside the range, above it.
By their numbers in this assay, from the lowest: compounds 1, 2 and 3 (each within the scatter of the next); then compound 4.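

Within the data shown here, changing only the aryl group on the ethenyl chain, with the chain and amide left in place, gives the first step beyond the scatter in this assay, namely a 4.0-fold higher number from compound 3 to compound 4 (0.60 log units; beyond the scatter) in this series. The wider swaps on the carbonyl carbon point the same way, with a 4.0-fold higher number from compound 2 to compound 4 (0.60 log units; beyond the scatter) and a 6.1-fold higher number from compound 1 to compound 4 (0.79 log units; beyond the scatter), so among these four compounds only the one bearing 4-methoxyphenyl stands apart, while the other three cannot be told apart. Nothing measured here explains this step.

From the compounds shown here alone, it remains open whether the step goes with the methoxy group itself or with its place on the ring. A 3-methoxyphenyl and a 4-(trifluoromethyl)phenyl on the same chain would separate those two readings, and a plain phenyl would give a reference point.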